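This account rests on a few compounds, and the source may have more. Where it says the series, first, only, none or still open, it means among the compounds named here.

Measured compounds in a functional assay on MGC-803 cells (Homo sapiens) for antiproliferative activity, read by MTT assay, with a stated time of 48 h; on this read-out higher numbers stand for weaker inhibition and lower numbers for stronger inhibition:
compound 1 `O=C(Nc1ccc(Cl)cc1)Nc1cccc(CNc2nccnc2Cl)c1`, 4980 nM
compound 2 `Cc1ccc(NC(=O)Nc2cccc(CNc3nccnc3Cl)c2)c(C)c1`, 10100 nM
compound 3 `Cc1ccccc1NC(=O)Nc1cccc(CNc2nccnc2Cl)c1`, 14000 nM

Compound 3 gives the highest number of the three; its gap to compound 2, a 1.4-fold higher number from compound 2 to compound 3 (0.14 log units; within the scatter), lies within the scatter, while a 2.8-fold higher number from compound 1 to compound 3 (0.45 log units; beyond the scatter) lies beyond it. Compound 4 `Cc1cccc(NC(=O)Nc2cccc(CNc3nccnc3Cl)c2)c1` differs from compound 3 by 3-methylphenyl in place of 2-methylphenyl on an amide-type nitrogen. For the measured compounds named here, no measured pair differs only in where the methyl sits, so the bearing steps are indirect: a 2.0-fold higher number from compound 1 to compound 2 (0.31 log units; beyond the scatter) and a 2.8-fold higher number from compound 1 to compound 3 (0.45 log units; beyond the scatter), both modest, and a 1.4-fold higher number from compound 2 to compound 3 (0.14 log units; within the scatter), within the scatter. Methyl changes on this ring have moved the number little, so a step no larger than the scatter is expected, a 1.3-fold lower number from compound 3 to compound 4 (0.10 log units; within the scatter). Compound 4 is estimated at 11000 nM, with a range of 4500 nM to 28000 nM.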

Compound 4, half-maximal inhibitory concentration: 14600 nM
Compound 4: the middle estimate sits 1.3-fold (0.12 log units) below what was measured; the measured number falls inside the stated range.
By their numbers in this assay, from the lowest: compound 1; then compounds 2, 3 and 4 (each within the scatter of the next).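

In this assay, for the compounds shown here, 3-methylphenyl in place of 2-methylphenyl on the amide-type nitrogen gives a 1.0-fold higher number from compound 3 to compound 4 (0.02 log units; within the scatter) and is the first direct read on where the methyl sits, with no separation between the two. The step from 2,4-dimethylphenyl to 3-methylphenyl, a 1.4-fold higher number from compound 2 to compound 4 (0.16 log units; within the scatter), also shows no separation, whereas a 2.9-fold higher number from compound 1 to compound 4 (0.47 log units; beyond the scatter) keeps 4-chlorophenyl apart from 3-methylphenyl. No evidence is available on what lies behind these results. Still open, going by these compounds, is whether that gap follows the chlorine itself or its place on the ring: 4-methylphenyl, 3-chlorophenyl or 2-chlorophenyl on the same nitrogen would separate the two readings.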